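Fluorophenyl Variation and Inhibition at a Single Concentration

A few compounds are considered here, and "the series" means these few. Any claim that something is new, unique, unknown or untested is made for them only; others in the source may bear on it.

Compound 2 `Cc1n[nH]c2ccc(-c3nc4cnc(N5CCN(C)CC5)cn4c3Nc3cccc(F)c3)cc12` carries a 3-fluorophenyl on a nitrogen on an aromatic ring of the shared core. Among the compounds with values here, in a functional assay on CWR22R cells (Homo sapiens) for inhibition, with a stated time of 120 h, tested at 10 uM (a lower number here means less inhibition, a higher number more inhibition at the concentration tested (going by the name of the read-out)), compound 2 gives 5.41%, the highest of the two numbers measured so far. Within the data shown here, its only neighbour is compound 1 `Cc1n[nH]c2ccc(-c3nc4cnc(N5CCN(C)CC5)cn4c3Nc3ccccc3F)cc12`, which in this assay gives 0%; the one measured step, a number 5.4 percentage points higher from compound 1 to compound 2 (within the scatter), lies within the scatter, so the two compounds cannot be told apart on inhibition.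

Compound 3 `Cc1n[nH]c2ccc(-c3nc4cnc(N5CCN(C)CC5)cn4c3Nc3ccc(F)cc3Br)cc12` differs from compound 2 in one place: 2-bromo-4-fluorophenyl in place of 3-fluorophenyl on a nitrogen on an aromatic ring. Among the measured compounds shown here, the only measured step that bears on this change is the one between compound 1 and compound 2, and that step stayed within the scatter. Nothing measured shows a change at this position that moved inhibition beyond the scatter, so compound 3 is expected to stay near its neighbours, with an estimated step of a number 0.4 percentage points lower from compound 2 to compound 3 (within the scatter) in this assay that is not beyond the scatter. Compound 3 is therefore estimated at 5% in this assay, with a range from -5% to 20%.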

Compound 3, a percentage reported as inhibition, at one concentration (the size of the read-out at that concentration, not a potency): 4.41%
Compound 3: the middle estimate sits 0.6 percentage points above what was measured; the measured number falls inside the stated range.
By their numbers in this assay, from the lowest: compounds 1, 3 and 2 (each within the scatter of the next).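

The earlier pair differed only in where a single fluorine sat on the phenyl ring, whereas compound 3 carries two halogens on that ring, a bromine as well as a fluorine, and one more heavy atom. Even so, in this assay the change to 2-bromo-4-fluorophenyl gives only a small step in either comparison (a number 1 percentage points lower from compound 2 to compound 3 (within the scatter); a number 4.4 percentage points higher from compound 1 to compound 3 (within the scatter)), so the three compounds cannot be told apart on inhibition, and this position on the nitrogen accepts the larger, doubly halogenated ring without a change beyond the scatter. Nothing available here explains this outcome or links it to any property of the bromine or the fluorine.

The compounds shown leave open whether any group on this nitrogen can move inhibition beyond the scatter, since all three carry a phenyl ring with only halogens on it. A phenyl ring bearing an amine or a carboxylic acid, or a longer carbon chain in place of the ring, therefore remains an open case at this position.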